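Methoxy on the phenyl ring of compound 1

This account rests on a few compounds, and the source may have more. Where it says the series, first, only, none or still open, it means among the compounds named here.

Compounds measured in a functional assay on Jurkat cells (Homo sapiens) for antiproliferative activity, read by WST assay, with a stated time of 72 h; on this read-out higher numbers stand for weaker inhibition and lower numbers for stronger inhibition:
compound 1 `COc1ccc2[nH]c(-c3nc(-c4ccccc4)no3)cc2c1` — > 50000 nM
compound 2 `Oc1ccc2[nH]c(-c3nc(-c4ccccc4)no3)cc2c1` — 26900 nM
compound 3 `Clc1ccc2[nH]c(-c3nc(-c4ccccc4)no3)cc2c1` — > 50000 nM

Compound 1 `COc1ccc2[nH]c(-c3nc(-c4ccccc4)no3)cc2c1` sits at a limit of the assay, > 50000 nM, not at a number. Compound 3 `Clc1ccc2[nH]c(-c3nc(-c4ccccc4)no3)cc2c1` also sits at a limit, > 50000 nM. Only compound 2 `Oc1ccc2[nH]c(-c3nc(-c4ccccc4)no3)cc2c1` returns a number, 26900 nM. Compound 1 thus stands at the limit that the limit of > 50000 nM in this assay, at which 2 of the 3 values shown sit, describes.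

Compound 4 `COc1ccc(-c2noc(-c3cc4cc(OC)ccc4[nH]3)n2)cc1` differs from compound 1 by methoxy in place of hydrogen on an aromatic carbon. Going by the values given here, none of the measured steps touches this phenyl ring: they all alter the substituent on the core, giving an at least 1.8-fold lower number from compound 1 to compound 2 (0.26 log units; that floor lies within the scatter), a step that the two limits leave unreadable from compound 1 to compound 3 and an at least 1.8-fold higher number from compound 2 to compound 3 (0.26 log units; that floor lies within the scatter). Among the compounds with values here, two of these steps are small and the third cannot be sized, so no step is available that speaks to the change in compound 4. With compound 1 at a limit, compound 4 is expected to show no step beyond the scatter and to remain near the limit. The estimate for compound 4 in this assay is 50000 nM, from 15000 nM to 200000 nM, which corresponds to the expected step of a number no higher from compound 1 to compound 4 (the limit leaves the size open).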

Compound 4, half-maximal inhibitory concentration: > 50000 nM
Compound 4: a limit, no number; the forecaster's own chance of this, stated with the estimate: 70%; the middle value sits exactly at the limit.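

Going by these compounds alone, compound 1 and compound 4 both stand at a limit of this assay, not at a number, so no step between them can be read: the limit of > 50000 nM in this assay, at which 3 of the 4 values shown sit. The compounds shown leave open whether phenyl and 4-methoxyphenyl differ at all in this read-out.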